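The compounds below may be only part of what the source reports. "The series", "measured", "known", "first", "only" and "open" are said of these compounds alone.

Of the compounds shown here, three from one series have been tested in a functional assay on KB 3-1 cells (Homo sapiens) for cytotoxicity, read by MTT assay, with a stated time of 68 h; a lower number here means a stronger inhibitor, a higher number a weaker inhibitor. Compound 1 `CC1(C)C(CC[C@@H]2[C@@]3(C)CC[C@@H](O)C(C)(C)O[C@@H]3CC[C@]2(C)O)C(CO)=CCC2C1CC[C@@]2(C)O` carries a hydroxy on a saturated chain carbon bound to a double-bonded ring carbon. In this assay compound 1 gives > 50000 nM, which is a limit of the assay and not a number. Compound 3 `CC1(C)O[C@@H]2CC[C@](C)(O)[C@H](CCC3C(CO)=CCC4C(CC[C@@]4(C)O)C3(C)C)[C@@]2(C)CCC1=O` carries the same hydroxymethyl, but its core differs from the core of compound 1, and the difference between the two cores is not broken down here. In this assay compound 3 gives > 50000 nM, again a limit rather than a number. Compound 2 `CC1=CCC2C(CC[C@@]2(C)O)C(C)(C)C1CC[C@@H]1[C@@]2(C)CCC(=O)C(C)(C)O[C@@H]2CC[C@]1(C)O` arises from compound 3 by hydrogen in place of hydroxy on a saturated chain carbon bound to a double-bonded ring carbon. In this assay compound 2 gives > 50000 nM, which is also a limit. The step that the two limits leave unreadable from compound 3 to compound 2 therefore has no readable size, because the limit of > 50000 nM in this assay, at which 3 of the 3 values shown sit, holds every value shown. Compound 4 `CC1=CCC2C(CC[C@@]2(C)O)C(C)(C)C1CC[C@@H]1[C@@]2(C)CC[C@@H](O)C(C)(C)O[C@@H]2CC[C@]1(C)O` arises from compound 1 by the same kind of change, (hydrogen in place of hydroxy on a saturated chain carbon bound to a double-bonded ring carbon), at a place described in the same words. With the measured step unreadable, the expected step is a number no higher from compound 1 to compound 4 (the limit leaves the size open), and it rests on compound 1 sitting at its limit > 50000 nM. Compound 4 is therefore expected to give 50000 nM, within a range from 20000 nM to 100000 nM, most probably again as a limit rather than a number.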

Compound 4, half-maximal inhibitory concentration: > 50000 nM
Compound 4 gave a limit, no number; the forecaster's own chance of this, stated with the estimate: 85%; the middle value sits exactly at the limit.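

No step can be read from compound 1 to compound 4 or between any other pair, since each compound gives only a limit in this assay and not a number: the limit of > 50000 nM in this assay, at which 4 of the 4 values shown sit. The compounds shown leave open whether the change from hydroxymethyl to methyl, or the difference between the two cores, alters the result in this assay at all, and what actual value any of these compounds has.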